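Coumarin series at A2b: limits throughout, one change tracked

A few compounds are considered here, and "the series" means these few. Any claim that something is new, unique, unknown or untested is made for them only; others in the source may bear on it.

Compound 1 `CCOc1cccc2cc(-c3ccc([N+](=O)[O-])cc3)c(=O)oc12`, compound 2 `CCOc1cccc2cc(-c3cc(OC)c(OC)c(OC)c3)c(=O)oc12` and compound 3 `Cc1cccc2cc(-c3ccc([N+](=O)[O-])cc3)c(=O)oc12` were tested in a functional assay on CHO cells for antagonist activity at adenosine receptor A2b (Homo sapiens), read by cAMP accumulation; on this read-out higher numbers stand for weaker inhibition and lower numbers for stronger inhibition. In this assay compound 1 gives only a limit of the assay, > 30000 nM. Compound 2 likewise gives only a limit, > 30000 nM. Compound 3 also gives a limit, > 30000 nM. The step from compound 1 to compound 3, (methyl in place of ethoxy on an aromatic carbon), is a step that the two limits leave unreadable from compound 1 to compound 3; all three values sit at the limit of > 30000 nM in this assay, at which 3 of the 3 values shown sit. How the core of compound 2 differs from that of compound 1 is not broken down here.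

Compound 4 `COc1cc(-c2cc3cccc(C)c3oc2=O)cc(OC)c1OC` remains to be measured; it differs from compound 2 by methyl in place of ethoxy on an aromatic carbon, the same change as from compound 1 to compound 3. For the measured compounds named here, because of the limit of > 30000 nM in this assay, at which 3 of the 3 values shown sit, no numeric step is readable, and the expected step that the limit leaves unreadable from compound 2 to compound 4 rests on compound 2 at > 30000 nM. Compound 4 is estimated at 60000 nM, most likely reported as a limit again.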

Compound 4, half-maximal inhibitory concentration: > 30000 nM
Compound 4 gave a limit, no number (the forecaster's own chance of this, stated with the estimate: 90%); the middle value lies beyond the limit too.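

No step can be read between compound 2 and compound 4, as each gives only a limit: the limit of > 30000 nM in this assay, at which 4 of the 4 values shown sit.

The compounds shown leave open whether methyl in place of ethoxy alters inhibition at all, and how any of these compounds ranks against another.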